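Bromophenyl in Place of Difluorophenyl on the Saturated Ring Carbon

The source may hold more compounds than are shown below. What is called first, only, known or untested is meant among the compounds shown, and "the series" means these compounds.

Three compounds have been measured in an assay on cells for inhibition of histone deacetylase 4 (Homo sapiens), read by fluorescence, with a stated time of 30 min; a lower number here means a stronger inhibitor, a higher number a weaker inhibitor:

Compound 1 `O=C1NC(=O)/C(=C\c2ccc(OCC(=O)N3N=C(c4ccccc4)CC3c3ccccc3Cl)cc2)S1`: 1200 nM
Compound 2 `O=C1NC(=O)/C(=C\c2ccc(OCC(=O)N3N=C(c4ccccc4)CC3c3ccc(C(F)(F)F)cc3)cc2)S1`: 1000 nM
Compound 3 `O=C1NC(=O)/C(=C\c2ccc(OCC(=O)N3N=C(c4ccccc4)CC3c3ccc(F)cc3F)cc2)S1`: 2200 nM

All three share the same core and differ only in the phenyl group on the saturated ring carbon. Compound 3 gives the highest of the three numbers, though the margins are slim: the step of a 1.8-fold higher number from compound 1 to compound 3 (0.26 log units; within the scatter) stays within the scatter, while the step of a 2.2-fold higher number from compound 2 to compound 3 (0.34 log units; beyond the scatter) lies just beyond it.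

Compound 4 `O=C1NC(=O)/C(=C\c2ccc(OCC(=O)N3N=C(c4ccccc4)CC3c3ccc(Br)cc3)cc2)S1` is the next candidate. It changes compound 3 as follows: 4-bromophenyl in place of 2,4-difluorophenyl on a saturated ring carbon. Like compound 2, compound 4 carries a single substituent on that phenyl ring, here a bromine rather than a trifluoromethyl group. Going by the values given here, the step that bears most directly is the one from compound 2 to compound 3, which raised the number modestly; the step from compound 1 to compound 3 adds that a differently substituted phenyl made little difference. Reversing the modest rise seen for compound 2 seems the most reasonable expectation, so a step of about a 2.0-fold lower number from compound 3 to compound 4 (0.30 log units; within the scatter) is expected, in the direction of a stronger inhibitor. Compound 4 is therefore estimated at 1100 nM, with a likely range from 500 nM to 2500 nM in this assay.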

Compound 4, half-maximal inhibitory concentration: 1200 nM
For compound 4 the middle estimate is 1.1-fold (0.04 log units) below the measured one; the measured number falls inside the stated range.
By their numbers in this assay, from the lowest: compounds 2, 1, 4 and 3 (each within the scatter of the next, the first and the last beyond it).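

In this assay, the 4-bromophenyl group of compound 4 cannot be told apart from any of the three earlier phenyl groups on this saturated ring carbon: the steps are a 1.8-fold lower number from compound 3 to compound 4 (0.26 log units; within the scatter) and a 1.2-fold higher number from compound 2 to compound 4 (0.08 log units; within the scatter) and no change at the digits printed from compound 1 to compound 4 (within the scatter). The gap between compound 2 and compound 3 had hinted that the substituents on this phenyl ring might matter, but that single step beyond the scatter, a 2.2-fold higher number from compound 2 to compound 3 (0.34 log units; beyond the scatter), now has compound 4 sitting within the scatter of both ends, so the four compounds read as one narrow band with no clear ranking. Nothing available here explains why these different phenyl groups give such similar numbers.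

As far as these compounds go, every group at this position is still a phenyl ring carrying a halogen or trifluoromethyl, so it remains open whether the band would hold for a phenyl ring bearing an amine or a carboxylic acid, or for a longer chain in place of the ring. Going by these compounds alone, also open is whether moving a single bromine to another place on the phenyl ring would change the number, since no pair here varies that alone.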